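A few compounds are considered here, and "the series" means these few. Any claim that something is new, unique, unknown or untested is made for them only; others in the source may bear on it.

For the measured compounds named here, in an ADME assay on microsomes from liver (Mus musculus) for metabolic stability, using NADPH, with a stated time of 10 min (a higher number here means that more of the compound is left, a lower number that less of the compound is left), three compounds on the shared core have numbers so far. Compound 1 `CN(C[C@H]1Cc2c(cccc2N2CCC(N)CC2)CN1)[C@H]1CCCc2cccnc21` gives 70.3% and compound 2 `CN(C[C@H]1Cc2c(cccc2N2C[C@H]3CNC[C@H]3C2)CN1)[C@H]1CCCc2cccnc21` gives 54.7% and compound 3 `CN1CCN(Nc2cccc3c2C[C@@H](CN(C)[C@H]2CCCc4cccnc42)NC3)CC1` gives 85.8% on the same read-out. Compound 2 is thus the lowest of the three, below compound 1 and further below compound 3, with both gaps beyond the scatter.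

Compound 4 `CN(C)C1CCN(c2cccc3c2C[C@H](CN(C)[C@H]2CCCc4cccnc42)NC3)CC1` has no number yet. It differs from compound 2 as follows: a group of 9 heavy atoms (7 carbon, 2 nitrogen; one six-membered non-aromatic ring with 1 hetero atom) in place of a group of 8 heavy atoms (6 carbon, 2 nitrogen; 2 five-membered non-aromatic rings with 1 hetero atom each), on an aromatic carbon with 4-(dimethylamino)piperidin-1-yl as the entering group, on an aromatic carbon.

Going by the values given here, one measured step bears on this change. That step is a number 15.6 percentage points lower from compound 1 to compound 2 (beyond the scatter) and it is modest, running from one six-membered ring to two five-membered rings. Compound 4 goes the opposite way in ring type, so a partial move back towards compound 1 at 70.3% is expected. Among the compounds with values here, no measured compound carries the 4-(dimethylamino)piperidin-1-yl group, and no measured step links compound 3 to the others, so a full return is not assumed.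

A modest rise is expected in this assay with the estimated step being a number 11.3 percentage points higher from compound 2 to compound 4 (beyond the scatter) in this series. The estimate for compound 4 is 66% with an expected range from 50% to 80% for the measurement.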

Compound 4, percent of the compound remaining: 70.2%
The estimate for compound 4 lay 4.2 percentage points below the measured number; low and high end bracket the measured number.
By their numbers in this assay, from the lowest: compound 2; then compounds 4 and 1 (each within the scatter of the next); then compound 3.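

In this assay, replacing amino with dimethylamino on a saturated ring carbon gives a number 0.1 percentage points lower from compound 1 to compound 4 (within the scatter), so this change to the group on the aromatic carbon does not separate the two compounds. Replacing the group with two five-membered non-aromatic rings by 4-(dimethylamino)piperidin-1-yl gives a number 15.5 percentage points higher from compound 2 to compound 4 (beyond the scatter), and with a number 15.6 percentage points lower from compound 1 to compound 2 (beyond the scatter) this places both compounds with a six-membered non-aromatic ring beyond the scatter from compound 2, so at this position the read-out follows the change of ring type and not the methyl groups on the amine, at least across these three compounds. Nothing measured here gives a reason for either step.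

On these data alone, it remains open whether a hydroxyl group or a carboxylic acid in place of the amine on that saturated ring carbon would stay level with compound 4 in this assay, or whether a single five-membered ring such as pyrrolidine would read like the six-membered ring or like the group in compound 2. Compound 3 differs from the others in more than one place, so its number cannot be tied to any single change.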